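The source may report more compounds than this note shows. Statements on the series, on what has been measured and on what is new or still open speak of the compounds shown alone.

Measured compounds in a functional assay on the whole organism (strain Swiss Albino) for inhibition, with Mus musculus as the target, in the writhing test, with a stated time of 1 h, at a dose of 100 mg/kg by the oral route; on this read-out higher numbers stand for more inhibition at the one dose given (going by the name of the read-out) and lower numbers for less inhibition:
compound 1 `COc1cc2c(cc1OC)C(CC(=O)O)CC2`: 44%
compound 2 `COc1cc2c(cc1OC)C(CC(=O)Nc1ccccc1)CC2`: 42.8%

Compound 2 sits within the scatter of compound 1: the step of a number 1.2 percentage points lower from compound 1 to compound 2 (within the scatter) shows that anilino in place of hydroxy on the carbonyl carbon left the read-out in this assay essentially where it was. Of the two numbers, compound 2 is the one from which the next change is taken.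

Compound 3 `COc1cc2c(cc1OC)C(CC(=O)Nc1cccc(Cl)c1)CC2` differs from compound 2 by chloro in place of hydrogen on an aromatic carbon. Among the measured compounds shown here, no measured step touches the aromatic ring of the anilino group; the only step available, a number 1.2 percentage points lower from compound 1 to compound 2 (within the scatter), concerns the carbonyl substituent and was within the scatter. On this basis no step beyond the scatter is expected from compound 2 to compound 3, and the expected step is a number 2.2 percentage points higher from compound 2 to compound 3 (within the scatter). Compound 3 is estimated at 45% in this assay, within the range 30% to 60%.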

Compound 3, a percentage reported as inhibition, in the whole organism at one dose (the size of the read-out at that dose, not a potency): 51.5%
The estimate for compound 3 lay 6.5 percentage points below the measured number; low and high end bracket the measured number.
By their numbers in this assay, from the lowest: compounds 2, 1 and 3 (each within the scatter of the next).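

In this assay, chloro on an aromatic carbon of the anilino ring, meta to a large group, gives a number 8.7 percentage points higher from compound 2 to compound 3 (within the scatter) and so brings this ring position into the comparison, though compound 2 and compound 3 remain within the scatter of each other. Set against the carboxylic acid, (3-chlorophenyl)amino in place of hydroxy on the carbonyl carbon gives a number 7.5 percentage points higher from compound 1 to compound 3 (within the scatter), so this larger substituent also leaves the read-out within the scatter of compound 1 at this one dose. Nothing measured on these compounds speaks to the reason for either step.

Still open, from the compounds shown here alone, is whether fluoro, methoxy or trifluoromethyl on this aromatic carbon would give a step beyond the scatter. Also open, going by these compounds, is how a methylene spacer between the amide nitrogen and the ring, or a benzylamine amide in place of the anilide, would read here.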